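Methyl for nitro on the hydroxy-bearing ring of the benzyloxy anilines

This account rests on a few compounds, and the source may have more. Where it says the series, first, only, none or still open, it means among the compounds named here.

Two compounds of this series have numbers in an assay on isolated protein for inhibition of Amine oxidase [flavin-containing] B (Homo sapiens), read by fluorescence and Amplex Red, with stated times of 15 min and 20 min; on this read-out lower numbers stand for stronger inhibition and higher numbers for weaker inhibition. Compound 1 `Cc1cccc(/C=N/c2ccc(OCc3ccccc3)cc2)c1O` carries a methyl on the hydroxy-bearing ring and gives 15500 nM. Compound 2 `O=[N+]([O-])c1ccc(O)c(/C=N/c2ccc(OCc3ccccc3)cc2)c1` carries a nitro instead and gives 60900 nM. Compound 2 thus stands at the weaker end of the two values, and the gap to compound 1 lies beyond the usual scatter of this assay.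

The next compound, compound 3 `Cc1ccc(O)c(/C=N/c2ccc(OCc3ccccc3)cc2)c1`, is not yet measured in this assay. Among the compounds with values here, its change from compound 2 is methyl in place of nitro on an aromatic carbon; the group that leaves is the nitro of compound 2 and the group that enters is a methyl, so the new compound carries the same small substituent type as compound 1, though no step between compound 1 and compound 3 has been worked out here.

Since compound 1 with its methyl gives 15500 nM while compound 2 with its nitro gives 60900 nM, the swap in compound 3 is expected to move the number back toward the stronger side, by a step of a 3.0-fold lower number from compound 2 to compound 3 (0.48 log units; beyond the scatter) in this assay. Compound 3 is therefore estimated at 20000 nM, with a range from 7000 nM to 60000 nM.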

Compound 3, half-maximal inhibitory concentration: 24600 nM
For compound 3 the middle estimate is 1.2-fold (0.09 log units) below the measured one; the measured number falls inside the stated range.
By their numbers in this assay, from the lowest: compounds 1 and 3 (each within the scatter of the next); then compound 2.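

In this assay the position para to a hydroxy group responds to the group it carries: methyl in place of nitro gives a 2.5-fold lower number from compound 2 to compound 3 (0.39 log units; beyond the scatter), a modest step but one beyond the scatter. Where the methyl sits counts for little on these numbers, since 2-hydroxy-5-methylphenyl in place of 2-hydroxy-3-methylphenyl gives a 1.6-fold higher number from compound 1 to compound 3 (0.20 log units; within the scatter), which lies within the scatter and leaves the two methyl compounds indistinguishable. Within the data shown here, the earlier pair changed both the group and its place at once, so compound 3 is the first to isolate the group at one position and the place of one group.

The numbers give no reason for either step, and nothing at hand bears on why nitro and methyl differ here. Still open, on these data alone, is whether an amine, a carboxylic acid or a longer chain such as propyl at this position would go beyond methyl, and whether a nitro in the place of the methyl of compound 1 would give a step of the same size.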